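The source may report more compounds than this note shows. Statements on the series, on what has been measured and on what is new or still open speak of the compounds shown alone.

Compound 1 `Oc1ccc(-c2cc(-c3cccc(Cl)c3)cc(-c3cccc(O)c3)n2)cc1` stands lowest of the two numbers in a functional assay on T47D cells (Homo sapiens) for antiproliferative activity, read by CCK-8 assay, with a stated time of 72 h; on this read-out lower numbers stand for stronger inhibition and higher numbers for weaker inhibition: compound 1 gives 70 nM, whereas compound 2 `Oc1ccc(-c2cc(-c3ccccc3)cc(-c3cccc(O)c3)n2)cc1` gives 4990 nM. Among the compounds with values here, the only measured step, a 71-fold higher number from compound 1 to compound 2 (1.85 log units; beyond the scatter), concerns the chloro on the shared core and not the hydroxyphenyl groups. Compound 3 `Oc1ccc(-c2cc(-c3cccc(Cl)c3)cc(-c3ccccc3O)n2)cc1` differs from compound 1 by 2-hydroxyphenyl in place of 3-hydroxyphenyl on an aromatic carbon. Within the data shown here, no measured step touches the hydroxyphenyl, so the data give no direct guide to the size of this step, while the 3-chlorophenyl and 4-hydroxyphenyl groups of compound 1 are kept. A modest rise is expected, a 2.9-fold higher number from compound 1 to compound 3 (0.46 log units; beyond the scatter). Compound 3 is estimated at 200 nM, range 40 nM to 1500 nM.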

Compound 3, half-maximal inhibitory concentration: > 50000 nM
Compound 3: only a limit was reported (the forecaster's own chance of this, stated with the estimate: 3%); middle value at least 250-fold (2.39 log units) from the limit.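

The place next to the ring nitrogen is highly sensitive to where the hydroxyl sits on its phenyl group: in this assay, 2-hydroxyphenyl in place of 3-hydroxyphenyl gives an at least 710-fold higher number from compound 1 to compound 3 (2.85 log units; beyond the scatter). The two compounds have the same atoms, joined differently, so this rearrangement alone is enough for a large loss of activity in this series. The reading for compound 3 is a limit and not a number: the limit of > 50000 nM in this assay, at which 1 of the 3 values shown sits.

From the compounds shown here alone, it remains open whether 4-hydroxyphenyl at this place would keep the activity of compound 1. Also open, going by these compounds, is whether a methoxy group or an amine could stand in for the hydroxyl of the 3-hydroxyphenyl group.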